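A cautious swap: pyridinyl for phenyl on the piperazine

A few compounds are considered here, and "the series" means these few. Any claim that something is new, unique, unknown or untested is made for them only; others in the source may bear on it.

Of the compounds shown here, three share one core and have been tested in an ADME assay on Vero cells (Chlorocebus sabaeus) for antiproliferative activity, read by MTT assay; a lower number here means a stronger inhibitor, a higher number a weaker inhibitor. Compound 1 `CN1CCN(c2nc(-c3cn(C)c4ccccc34)c3ccccc3n2)CC1` gives 50 ug/mL. Compound 2 `CN1CCN(c2nc(-n3ccc4ccccc43)c3ccccc3n2)CC1` gives 22.3 ug/mL. Compound 3 `c1ccc(N2CCN(c3nc(-n4ccc5ccccc54)c4ccccc4n3)CC2)cc1` gives 50 ug/mL, which is level with compound 1 at the digits shown, and together these two are the highest numbers of the three, meaning the weakest inhibition; compound 2 lies furthest away, with the lower number.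

For the measured compounds named here, the one measured change in one place is the step of a 2.2-fold higher number from compound 2 to compound 3 (0.35 log units; beyond the scatter), a modest weakening. Compound 4 `c1ccc(N2CCN(c3nc(-n4ccc5ccccc54)c4ccccc4n3)CC2)nc1` is not yet measured. It differs from compound 3 in one place: pyridin-2-yl in place of phenyl on an amine nitrogen in a ring.

Going by the values given here, no measured step shows what swapping phenyl for pyridin-2-yl does here; the only known step concerns phenyl against methyl at the same ring nitrogen, and it was small. A change of one ring atom within a six-membered aromatic ring is a much gentler alteration than that. The expectation is therefore a step of no change at the digits printed from compound 3 to compound 4 (within the scatter), that is, nothing beyond the scatter. Because compound 3 gives 50 ug/mL, the estimate for compound 4 stays close to it. Compound 4 is expected near 50 ug/mL, within 25 ug/mL to 100 ug/mL.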

Compound 4, half-maximal inhibitory concentration: 50 ug/mL
Compound 4: middle estimate and measured number agree at the digits printed; the range from low to high includes it.
By their numbers in this assay, from the lowest: compound 2; then compounds 1, 3 and 4 (each within the scatter of the next).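

In this assay, putting pyridin-2-yl in place of phenyl on the amine nitrogen of the piperazine gives no change at the digits printed from compound 3 to compound 4 (within the scatter), so at this position the ring nitrogen and hydrogen-bond acceptor that pyridin-2-yl brings leave the number where phenyl had it. Set against methyl at the same place, pyridin-2-yl gives a 2.2-fold higher number from compound 2 to compound 4 (0.35 log units; beyond the scatter), a step that matches a 2.2-fold higher number from compound 2 to compound 3 (0.35 log units; beyond the scatter), so for these three compounds the two aromatic rings stand together on the weaker side of methyl. No supporting measurement is available to explain either step.

Still open, from the compounds shown here alone, is where a hydrogen on that amine nitrogen, an ethyl chain, a benzyl group or pyridin-3-yl would fall relative to methyl and the two aromatic rings. Also open, going by these compounds, is whether the same swap of methyl for pyridin-2-yl would give a step of similar size on the core of compound 1, which carries methyl at this nitrogen.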